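The source may hold more compounds than are shown below. What is called first, only, known or untested is meant among the compounds shown, and "the series" means these compounds.

Values in a functional assay on HCT-116 cells (Homo sapiens) for inhibition, read by MTT assay, with a stated time of 48 h; on this read-out higher numbers stand for weaker inhibition and lower numbers for stronger inhibition:

- compound 1, `C[Se]c1ccc(N(C)c2nc(C3CC3)nc3ccccc23)cc1`: 15 nM
- compound 2, `COc1ccc(N(C)c2nc(C)nc3ccccc23)cc1[Se]C`: 28 nM
- compound 3, `COc1ccc(N(C)c2nc(C)nc3ccccc23)cc1[Se]C#N`: 34 nM

Compound 1 carries the lowest of the three numbers in this assay. Its nearest neighbour is compound 2, which lies within the scatter of it; compound 3 lies beyond the scatter of compound 1. Compound 2 and compound 3 share a core, and the difference between the core of compound 1 and that of compound 2 is not broken down here.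

Within the shared core of compound 2 and compound 3 one change is measured, (cyano in place of methyl on a selenium). In this assay it gave a 1.2-fold higher number from compound 2 to compound 3 (0.08 log units; within the scatter), which is within the scatter, so on these two compounds the change is effectively neutral.

The unmeasured compound 4, `CN(c1ccc([Se]C#N)cc1)c1nc(C2CC2)nc2ccccc12`, stands to compound 1 as compound 3 stands to compound 2: the difference is cyano in place of methyl on a selenium. The two place descriptions are the same word for word, so this is the same change on a different core. Among the compounds with values here, with only one measured instance of it, the expectation for compound 4 rests on that single step. Because of a 1.2-fold higher number from compound 2 to compound 3 (0.08 log units; within the scatter), which is within the scatter, a step of about a 1.2-fold higher number from compound 1 to compound 4 (0.08 log units; within the scatter) is expected. Compound 4 is therefore estimated at 18 nM, with a plausible range from 9 nM to 36 nM.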

Compound 4, half-maximal inhibitory concentration: 62 nM
The estimate for compound 4 lay 3.4-fold (0.54 log units) below the measured number; measured number above the stated range.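

In this assay, cyano in place of methyl on a selenium whose other neighbour is an aromatic carbon gives a 4.1-fold higher number from compound 1 to compound 4 (0.62 log units; beyond the scatter), and on the core of compound 1 the change therefore costs measurable inhibition rather than being neutral. The size of the step does not carry from one core to the other, and the neutral result on the shared core of compound 2 and compound 3 cannot be taken as a general rule for this change in the series: the same change on two cores in this assay, a 1.2-fold higher number (0.08 log units; within the scatter) from compound 2 to compound 3 and a 4.1-fold higher number (0.62 log units; beyond the scatter) from compound 1 to compound 4, 3.4-fold (0.53 log units) apart, beyond the scatter of two such steps. This rests on a single pair of compounds for each core, and it does not show which of the differences between the two cores sets the steps apart, nor how the change would behave on a third core.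

Only methyl and cyano appear on the selenium in the compounds shown, and it remains open whether a longer chain such as ethyl, or a group such as a carboxylic acid or an amine at the end of a short chain, would stay close to compound 1 at 15 nM in this assay. Also open, from the compounds shown here alone, is whether any such replacement would give the same step on both cores or would again depend on the core.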